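Swapping Chloro for Amino on a Fused Two-Ring Core

The source may report more compounds than this note shows. Statements on the series, on what has been measured and on what is new or still open speak of the compounds shown alone.

compound 1 `CN1CCN(c2ccc(C#Cc3c(F)cccc3F)cc2)CC1`: 19.9%
compound 2 `Fc1cccc(F)c1C#Cc1ccc2c(Cl)ccnc2c1`: 23.1%
compound 3 `Nc1ccnc2ccc(C#Cc3c(F)cccc3F)cc12`: 66.2%

These three compounds were measured in a functional assay on LS174T cells (Homo sapiens) for inhibition, with a stated time of 4 days, tested at 1 uM; a lower number here means a weaker effect, a higher number a stronger effect of the compound at the concentration tested. Compound 2 stands second highest of the three; compound 1 lies within the scatter of it, while compound 3 lies beyond the scatter above it. The unmeasured compound 4 `Nc1ccnc2cc(C#Cc3c(F)cccc3F)ccc12` differs from compound 2 in one place: amino in place of chloro on an aromatic carbon. Among the compounds with values here, no step between measured compounds covers this change. Compound 3, which also carries an amino group, gives 66.2% in this assay, so a step upward beyond the scatter is expected, though with wide uncertainty. Compound 4 is estimated at 45%, with a range from 15% to 75%. The expected step is a number 21.9 percentage points higher from compound 2 to compound 4 (beyond the scatter).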

Compound 4, a percentage reported as inhibition, at one concentration (the size of the read-out at that concentration, not a potency): 23.6%
For compound 4 the middle estimate is 21.4 percentage points above the measured one; the measured number falls inside the stated range.
By their numbers in this assay, from the lowest: compounds 1, 2 and 4 (each within the scatter of the next); then compound 3.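

In this assay, amino in place of chloro on the aromatic carbon opposite the ring nitrogen gives a number 0.5 percentage points higher from compound 2 to compound 4 (within the scatter). On this core, then, no difference can be read between these two groups at this position, even though amino brings a hydrogen-bond donor and acceptor that chloro lacks. Nothing at hand explains this result. Going by these compounds, it remains open whether a methoxy or dimethylamino group on the same carbon would stand clear of both compounds. On these data alone, whether compound 2 and compound 4 would also stay this close at other concentrations remains open too.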